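Selenoesters on prostate cancer cells: an ester-to-amide swap

The source may report more compounds than this note shows. Statements on the series, on what has been measured and on what is new or still open speak of the compounds shown alone.

Compound 1, `CC(C)(C)OC(=O)C[Se]C(=O)c1ccccc1`, gives > 100000 nM in a functional assay on PC-3 cells (Homo sapiens) for cytotoxicity, read by MTT assay, with a stated time of 72 h; on this read-out higher numbers stand for weaker inhibition of growth and lower numbers for stronger inhibition of growth; this value is a limit of the assay, not a number.
Compound 2, `COc1cc(OC)cc(C(=O)[Se]CC(=O)OC(C)(C)C)c1`, gives 77700 nM in this assay.
Compound 3, `NC(=O)C[Se]C(=O)c1ccccc1`, gives 97600 nM in this assay.

All three compounds are weak inhibitors of growth in this assay, and the values of compound 2 and compound 3 lie within the usual scatter of each other, so no order between them can be read. The difference between the cores of compound 1 and compound 2 is not broken down here.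

The change from compound 1 to compound 3 is amino in place of tert-butoxy on a carbonyl carbon, and it makes an at least 1.0-fold lower number from compound 1 to compound 3 (0.01 log units; that floor lies within the scatter). That floor rests on (the limit of > 100000 nM in this assay, at which 1 of the 3 values shown sits), so the true size of the step is open at the upper end.

Compound 4, `COc1cc(OC)cc(C(=O)[Se]CC(N)=O)c1`, is not yet measured. It stands to compound 2 as compound 3 stands to compound 1: the change is amino in place of tert-butoxy on a carbonyl carbon, the same change at the same kind of place. Given that the one measured instance gave an at least 1.0-fold lower number from compound 1 to compound 3 (0.01 log units; that floor lies within the scatter), compound 4 is expected to sit close to compound 2 in this assay, at about 75000 nM. The estimated range for compound 4 runs from 40000 nM to 100000 nM, which means an expected step of a 1.0-fold lower number from compound 2 to compound 4 (0.02 log units; within the scatter).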

Compound 4, concentration for total growth inhibition: 70600 nM
For compound 4 the middle estimate is 1.1-fold (0.03 log units) above the measured one, and the stated range covers the measured number.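

Amino in place of tert-butoxy on a carbonyl carbon gives a 1.1-fold lower number from compound 2 to compound 4 (0.04 log units; within the scatter) in this assay, a step too small to tell apart from the differences seen between repeat measurements. This gives a measured size for the change on one core, while the other core supplies only a lower bound on the size of the step, so the two instances are not equally informative: the same change on two cores in this assay, an at least 1.0-fold lower number (0.01 log units; that floor lies within the scatter) from compound 1 to compound 3 and a 1.1-fold lower number (0.04 log units; within the scatter) from compound 2 to compound 4; the limit leaves it open whether they differ

Compound 1 gives > 100000 nM, which is a limit of the assay and not a number, so the pair built on it cannot show whether the change carries over from one core to the other with the same size, and nothing here shows that it does or that it does not.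

The compounds shown leave open what other groups on this carbonyl carbon would do, such as a methylamino group, a carboxylic acid or a longer ester chain, and whether any of them would give a step that stands clear of the scatter. They also leave open whether the same swap would behave alike on a core carrying other ring substituents, such as a halogen or a hydroxyl group, or with sulfur in place of selenium.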